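This account rests on a few compounds, and the source may have more. Where it says the series, first, only, none or still open, it means among the compounds named here.

Measured so far:
- compound 1, `COc1c(/C=C2/C(=O)Nc3ccc(Cl)cc32)c2ccccc2n1-c1ccccc1`: 6310 nM
- compound 2, `COc1cc2c(/C=C3/C(=O)Nc4ccc(O)cc43)c(Cl)n(Cc3cc(OC)c(OC)c(OC)c3)c2cc1C`: 2290 nM
- compound 3, `COc1cc2c(cc1C)NC(=O)/C2=C/c1c(Cl)n(Cc2cc(OC)c(OC)c(OC)c2)c2cc(C)c(OC)cc12`: 16600 nM

All three compounds share a core in which an indole carries a double bond to an oxindole. In a functional assay on cells (Cancer cell lines, Homo sapiens) for cytotoxicity, with a stated time of 48 h (a higher number here means a weaker inhibitor of growth, a lower number a stronger inhibitor of growth), compound 1 gives 6310 nM, the second highest of the three numbers. Compound 2 gives 2290 nM in this assay, a lower number than compound 1 by a gap beyond the usual scatter. Compound 3 gives 16600 nM in this assay, a higher number than compound 1, again by a gap beyond the scatter. Compounds 2 and 3 differ from compound 1 in several places at once, so none of the recorded numbers isolates the effect of a single change.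

Compound 4, `COc1ccc2c(c1)/C(=C\c1c(OC)n(-c3ccccc3)c3ccccc13)C(=O)N2`, is compound 1 altered in one place: methoxy in place of chloro on an aromatic carbon. For the measured compounds named here, no measured pair shows this change, so the expectation rests on compound 1 alone and on the spread of the three numbers. A modest step, not clearly beyond the scatter, is the expectation, with a slight lean toward a lower number. Compound 4 is therefore expected to give about 5000 nM in this assay, with a likely range from 1500 nM to 16000 nM. The expected step of a 1.3-fold lower number from compound 1 to compound 4 (0.10 log units; within the scatter) is small.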

Compound 4, concentration for 50% growth inhibition: 1740 nM
Compound 4: middle estimate off by 2.9-fold (0.46 log units), on the high side; the measured number falls inside the stated range.
By their numbers in this assay, from the lowest: compounds 4 and 2 (each within the scatter of the next); then compound 1; then compound 3.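

In this assay, for the compounds shown here, putting methoxy in place of chloro on this aromatic carbon gives a 3.6-fold lower number from compound 1 to compound 4 (0.56 log units; beyond the scatter), the first change in one place that can be read in this set, and it shows that the number responds to what sits at this position on the shared core. The counted difference is small: chloro, with 1 heavy atom, leaves, and methoxy, with 2 heavy atoms and 1 hydrogen-bond acceptor, enters, with no ring or net charge involved, yet the step still lies beyond the usual scatter. Nothing measured here tells why the number moves with this change.

Going by these compounds, with only chloro and methoxy compared directly at this position, it remains open how an amine, a carboxylic acid or a longer chain such as propoxy would fare there. Also open, on these data alone, is whether the same swap would move the number in the same direction on a core carrying the other features of compound 2 or compound 3, which differ from compound 1 in several places.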